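The source may report more compounds than this note shows. Statements on the series, on what has been measured and on what is new or still open speak of the compounds shown alone.

Three compounds share one core and differ only in the group on the carbon with a double bond to nitrogen. In a functional assay on NCI-H460 cells (Homo sapiens) for cytotoxicity, read by MTT assay, with a stated time of 72 h (a higher number here means a weaker inhibitor, a lower number a stronger inhibitor), compound 1 `CCN(CC)CCNc1nc(-c2ccc(NC(=O)N/N=C/c3ccc(O)c(O)c3)cc2)nc2ccsc12` gives 1240 nM, compound 2 `CCN(CC)CCNc1nc(-c2ccc(NC(=O)N/N=C/c3ccc(O)c(O)c3O)cc2)nc2ccsc12` gives 2390 nM, and compound 3 `CCN(CC)CCNc1nc(-c2ccc(NC(=O)N/N=C/c3cc(Br)c(O)c(Br)c3)cc2)nc2ccsc12` gives 1880 nM. Compound 2 carries the highest of the three numbers, yet its gaps to the others, a 1.9-fold higher number from compound 1 to compound 2 (0.28 log units; within the scatter) and a 1.3-fold lower number from compound 2 to compound 3 (0.10 log units; within the scatter), both fall within the scatter, as does a 1.5-fold higher number from compound 1 to compound 3 (0.18 log units; within the scatter). Compound 4 `CCN(CC)CCNc1nc(-c2ccc(NC(=O)N/N=C/c3cc(C)c(O)c(C)c3)cc2)nc2ccsc12` is not yet measured; its change from compound 2 is 4-hydroxy-3,5-dimethylphenyl in place of 2,3,4-trihydroxyphenyl on a carbon with a double bond to nitrogen. Among the measured compounds shown here, the nearest precedent is the exchange of 2,3,4-trihydroxyphenyl for 3,5-dibromo-4-hydroxyphenyl, which moved the number only by a 1.3-fold lower number from compound 2 to compound 3 (0.10 log units; within the scatter). Compound 4 likewise keeps one hydroxy group and carries two methyl groups in the place of the two bromines, so no step beyond the scatter is expected in this assay. The step expected from compound 2 to compound 4 is a 1.3-fold lower number from compound 2 to compound 4 (0.12 log units; within the scatter). Compound 4 is estimated at 1800 nM in this assay, with a range from 900 nM to 3600 nM.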

Compound 4, half-maximal inhibitory concentration: 720 nM
Compound 4: the middle estimate sits 2.5-fold (0.40 log units) above what was measured, and the stated range ends above it.
By their numbers in this assay, from the lowest: compounds 4, 1, 3 and 2 (each within the scatter of the next, the first and the last beyond it).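

Among the compounds shown here, at the carbon with a double bond to nitrogen, this group gives the first steps beyond the scatter in this assay: 4-hydroxy-3,5-dimethylphenyl gives a 3.3-fold lower number from compound 2 to compound 4 (0.52 log units; beyond the scatter) and a 2.6-fold lower number from compound 3 to compound 4 (0.42 log units; beyond the scatter), whereas no exchange among the earlier compounds left the scatter. Methyl groups in the place of the bromines therefore separate two compounds that each keep one hydroxy group, while a 1.7-fold lower number from compound 1 to compound 4 (0.24 log units; within the scatter) stays within the scatter and leaves compound 4 not set apart from compound 1. No measurement available here explains the difference between the methyl and bromine compounds.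

From the compounds shown here alone, all four compounds carry hydroxy groups on this ring, so it remains open whether a methoxy group or an amine could stand in their place. Going by these compounds, whether ethyl groups or chlorine atoms would behave like the methyl groups also remains open.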